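Three Compounds at the Assay Limit, a Fourth Expected There

The source may hold more compounds than are shown below. What is called first, only, known or untested is meant among the compounds shown, and "the series" means these compounds.

Compound 1, `CCc1nnc(SCC(=O)c2ccccc2)n1N1C(=O)c2ccccc2C1=O`: in a functional assay on A549 cells (Homo sapiens) for cytotoxicity, read by MTT assay, with a stated time of 48 h (a lower number here means a stronger inhibitor, a higher number a weaker inhibitor), compound 1 gives > 200000 nM, which is a limit.
Compound 2, `CCc1nnc(SC)n1N1C(=O)c2ccccc2C1=O`: compound 2 gives > 200000 nM, also a limit.
Compound 3, `CCCc1nnc(SCC(=O)c2ccccc2)n1N1C(=O)c2ccccc2C1=O`: compound 3 gives > 200000 nM, again a limit.

Every value shown sits at the limit of > 200000 nM in this assay, at which 3 of the 3 values shown sit. The change from compound 1 to compound 2 is hydrogen in place of benzoyl on a saturated chain carbon bound to a sulfur, and the step it made, a step that the two limits leave unreadable from compound 1 to compound 2, cannot be sized. The cores of compound 1 and compound 3 differ by methyl in place of hydrogen on a saturated chain carbon, two bonds along the chain from an aromatic carbon, a step measured as a step that the two limits leave unreadable from compound 1 to compound 3.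

Compound 4, `CCCc1nnc(SC)n1N1C(=O)c2ccccc2C1=O`, is not yet measured. It differs from compound 3 by hydrogen in place of benzoyl on a saturated chain carbon bound to a sulfur, the same change as from compound 1 to compound 2, at the same place word for word. Since every value shown sits at the limit of > 200000 nM in this assay, at which 3 of the 3 values shown sit, compound 4 is expected to give 300000 nM, most likely again only a limit, a step that the limit leaves unreadable from compound 3 to compound 4.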

Compound 4, half-maximal inhibitory concentration: > 200000 nM
Compound 4 was reported as a limit; the forecaster's own chance of this, stated with the estimate: 90%; the middle value is on the limit's open side.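

The steps linking compound 4 to compound 3 and to compound 2 join limits only, so no new step can be read. The compounds shown leave open how strong any of them is in this assay, and what either change does there: the limit of > 200000 nM in this assay, at which 4 of the 4 values shown sit.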